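Swapping Methoxy for Bromo on the Aromatic Ring

The source may report more compounds than this note shows. Statements on the series, on what has been measured and on what is new or still open speak of the compounds shown alone.

Of the compounds shown here, two have so far been tested in an ADME assay on SUP-T1 cells (Homo sapiens) for cytotoxicity, read by MTT assay, with a stated time of 16 h; a higher number here means that more compound is tolerated, a lower number that less compound is tolerated. Compound 1 `CCOC(=O)C1=C(C)NC(=O)NC1c1ccc(O)cc1` gives 132000 nM. Compound 2 `CCOC(=O)C1=C(C)NC(=S)NC1c1ccc(OC)cc1` gives 110000 nM, the lowest of the two numbers, although compound 1 lies within the scatter of it, so the two cannot be told apart. Compound 3 `CCOC(=O)C1=C(C)NC(=S)NC1c1ccc(Br)cc1` has not yet been measured; it differs from compound 2 by bromo in place of methoxy on an aromatic carbon. Among the measured compounds shown here, no measured pair shows what such a change does in this assay, so the step is expected to stay within the scatter, estimated as a 1.1-fold lower number from compound 2 to compound 3 (0.04 log units; within the scatter). Compound 3 is therefore expected to give about 100000 nM, somewhere between 40000 nM and 250000 nM.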

Compound 3, half-maximal cytotoxic concentration: 136000 nM
The estimate for compound 3 lay 1.4-fold (0.13 log units) below the measured number, within the range that was stated.
By their numbers in this assay, from the lowest: compounds 2, 1 and 3 (each within the scatter of the next).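

Among the compounds shown here, this is the first pair that isolates a single change at this position: in this assay, bromo in place of methoxy gives a 1.2-fold higher number from compound 2 to compound 3 (0.09 log units; within the scatter) and so cannot be told apart from no effect. On this aromatic carbon, para to a large group, the two groups therefore give indistinguishable tolerance, even though they differ in size and in hydrogen-bond acceptors. No measured information offers an explanation for this result. On these data alone, whether an amine or a carboxylic acid on this carbon would move the number beyond the scatter remains open.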